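The source may hold more compounds than are shown below. What is called first, only, known or untested is meant among the compounds shown, and "the series" means these compounds.

Working notes on the series. Compound 1 `COC(=O)[C@@]1(C)CCC=C2[C@@H]1CC[C@@H](C)[C@]2(C)Cc1c[nH]c2ccc(Cl)cc12` gives 20000 nM in a functional assay on WiDr cells (Homo sapiens) for inhibition, read by sulforhodamine B assay, with a stated time of 48 h (on this read-out lower numbers stand for stronger inhibition of growth and higher numbers for weaker inhibition of growth), and compound 2 `COC(=O)[C@@]1(C)CCC=C2[C@@H]1CC[C@@H](C)[C@]2(C)Cc1c(C)[nH]c2ccc(Cl)cc12` gives 18000 nM in this assay. Among the compounds with values here, the single change between them is methyl in place of hydrogen on an aromatic carbon, and the step it made is a 1.1-fold lower number from compound 1 to compound 2 (0.05 log units; within the scatter). Compound 3 `COC(=O)[C@@]1(C)CC[C@@H]2C3=C1CC[C@@H](C)[C@]3(C)Cc1c2[nH]c2ccccc12` gives 4000 nM in this assay; the difference between its core and the core of compound 1 is not broken down here. Compound 3 stands with the lowest number of the three, with compound 2 and compound 1 both beyond the scatter above it.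

Compound 4 `COC(=O)[C@@]1(C)CC[C@@H]2C3=C1CC[C@@H](C)[C@]3(C)Cc1c2[nH]c2ccc(C)cc12` differs from compound 3 by methyl in place of hydrogen on an aromatic carbon. This is the same kind of change as that from compound 1 to compound 2, not the same: there the methyl entered on a five-membered aromatic ring with 1 nitrogen, next to the ring nitrogen and next to the ring atom that bears a large group; here it enters on a six-membered aromatic ring of carbon only, meta to a fused ring and para to a fused ring. Compound 4 is expected to show a step of a 1.1-fold lower number from compound 3 to compound 4 (0.06 log units; within the scatter), beside the measured 1.1-fold lower number from compound 1 to compound 2 (0.05 log units; within the scatter), because compound 2 gives 18000 nM where compound 1 gives 20000 nM. For compound 4 the estimate in this assay is 3500 nM, expected to fall between 1500 nM and 9000 nM.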

Compound 4, concentration for 50% growth inhibition: 19000 nM
Estimate against measurement, compound 4: 5.4-fold (0.73 log units) below, and the stated range ends below it.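

In this assay the change of methyl in place of hydrogen on an aromatic carbon gives a 4.8-fold higher number from compound 3 to compound 4 (0.68 log units; beyond the scatter) and so loses the lower number that set compound 3 apart. The step measured on the core of compound 1 did not carry over to the core of compound 3, and the two steps differ: the same change on two cores in this assay, a 1.1-fold lower number (0.05 log units; within the scatter) from compound 1 to compound 2 and a 4.8-fold higher number (0.68 log units; beyond the scatter) from compound 3 to compound 4, 5.3-fold (0.72 log units) apart, beyond the scatter of two such steps. This does not show whether the core or the place of the methyl accounts for the gap: on compound 2 the methyl sits on a five-membered aromatic ring with 1 nitrogen, on compound 4 on a six-membered aromatic ring of carbon only, and one pair on each core cannot separate the two.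

The compounds shown leave open how the core of compound 3 responds at this same place to a group other than methyl, such as a methoxy or an amine. Also open, as far as these compounds go, is whether the methyl ester shared by all four compounds can give way to a carboxylic acid.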